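Replacing methoxy with methyl in compound 2

This account rests on a few compounds, and the source may have more. Where it says the series, first, only, none or still open, it means among the compounds named here.

Compound 1 `COc1ccc(C2CC(c3ccc(Cl)cc3)=NN2C(=O)c2cc3ccccc3o2)cc1`: 5.74 ug/mL
Compound 2 `COc1ccc(C2CC(c3ccc(F)cc3)=NN2C(=O)c2cc3ccccc3o2)cc1`: 23 ug/mL

Both values come from a functional assay on A2780 cells (Homo sapiens) for antiproliferative activity, read by MTT assay, with a stated time of 72 h; a lower number here means a stronger inhibitor, a higher number a weaker inhibitor. Of the pair, compound 2 has the higher number, 23 ug/mL, and so is the weaker inhibitor. Compound 3 `Cc1ccc(C2CC(c3ccc(F)cc3)=NN2C(=O)c2cc3ccccc3o2)cc1` keeps the rest of compound 2 but has methyl in place of methoxy on an aromatic carbon, para to a large group (methyl in place of methoxy on an aromatic carbon). Among the compounds with values here, the only measured step, a 4.0-fold higher number from compound 1 to compound 2 (0.60 log units; beyond the scatter), was modest but beyond the scatter. That step exchanged chloro for fluoro and left the methoxy group untouched, so it bears on this change only loosely, as a rough guide to size. Within the data shown here, no measured pair tests the change from 4-methoxyphenyl to 4-methylphenyl, so no firm direction can be expected. The expected step is small, a 1.2-fold lower number from compound 2 to compound 3 (0.06 log units; within the scatter). In this assay, compound 3 is estimated at 20 ug/mL, with an expected range of 8 ug/mL to 50 ug/mL.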

Compound 3, half-maximal inhibitory concentration: > 50 ug/mL
Compound 3: a limit, no number (the forecaster's own chance of this, stated with the estimate: 5%); middle value at least 2.5-fold (0.39 log units) away from the limit.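

At the place on the aromatic ring para to a large group, the change from 4-methoxyphenyl to 4-methylphenyl is not silent in this assay: it gives an at least 2.1-fold higher number from compound 2 to compound 3 (0.33 log units; beyond the scatter). Compound 3 stands at a limit of the assay and not at a number: the limit of > 50 ug/mL in this assay, at which 1 of the 3 values shown sits. The earlier pair spoke only to chloro and fluoro, whereas this step shows that, with fluoro kept, the methoxy group cannot be exchanged for methyl without a weaker result.

As far as these compounds go, the full size of the step stays unknown, as the limit gives only its smallest possible value. Also open, from the compounds shown here alone, are whether hydroxy, ethoxy or chloro at this place would hold the level of compound 2, and whether the same exchange would weaken the chloro compound 1 as well.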